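The source may hold more compounds than are shown below. What is called first, only, known or untested is meant among the compounds shown, and "the series" means these compounds.

In an ADME assay on SH-SY5Y cells (Homo sapiens) for cytotoxicity, read by MTT assay, with a stated time of 48 h (on this read-out higher numbers stand for weaker inhibition and lower numbers for stronger inhibition), compound 1 `COc1ccc(C(=O)/C=C/c2ccc(C(=O)O)cc2)c(O)c1` gives > 100000 nM, which is a limit of the assay and not a number. Compound 2 `COC(=O)c1ccc(/C=C/C(=O)c2ccc(OC)cc2O)cc1` gives > 100000 nM, which is also only a limit. For the measured compounds named here, the single measured step, a step that the two limits leave unreadable from compound 1 to compound 2, therefore has no readable size, and all that can be said is the limit of > 100000 nM in this assay, at which 2 of the 2 values shown sit. Compound 3 `CCOCCOc1ccc(/C=C/C(=O)c2ccc(OC)cc2O)cc1` carries 2-ethoxyethoxy in place of methoxycarbonyl on an aromatic carbon. That unreadable step gives no firm size or direction, so a result near the limit is expected. The estimated step is an at least 1.2-fold lower number from compound 2 to compound 3 (0.09 log units; that floor lies within the scatter). Compound 3 is expected at 80000 nM, with an estimated range of 25000 nM to 150000 nM.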

Compound 3, half-maximal inhibitory concentration: > 100000 nM
Compound 3: no number, only a limit; the forecaster's own chance of this, stated with the estimate: 60%; at least 1.2-fold (0.09 log units) between middle value and limit.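

For the compounds shown here, compound 1, compound 2 and compound 3 each give only a limit and not a number, so no step among them can be read: the limit of > 100000 nM in this assay, at which 3 of the 3 values shown sit. The compounds shown leave open how far each one lies beyond that limit, and whether any of these group changes alters the result.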